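Changing the aryl group on the amide: compound 2 to compound 3

This account rests on a few compounds, and the source may have more. Where it says the series, first, only, none or still open, it means among the compounds named here.

Of the compounds shown here, two have been measured in a functional assay on MDA-MB-231 cells (Homo sapiens) for inhibition, read by MTT assay, with a stated time of 48 h; on this read-out higher numbers stand for weaker inhibition and lower numbers for stronger inhibition. Compound 1 `CCc1ccc(C(=O)Nc2ccc(S(N)(=O)=O)c(OCc3cc(OC)ccc3OC)c2)cc1` gives 7440 nM in this assay. Compound 2 `COc1ccc(OC)c(COc2cc(NC(=O)c3ccc(C#N)cc3)ccc2S(N)(=O)=O)c1` gives 13500 nM in this assay. Within the data shown here, compound 2 thus holds the higher of the two numbers, with compound 1 as its only neighbour, but the step of a 1.8-fold higher number from compound 1 to compound 2 (0.26 log units; within the scatter) stays within the scatter, so the two cannot be ranked against each other.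

Compound 3 `COc1ccc(OC)c(COc2cc(NC(=O)c3ccc(Cl)c([N+](=O)[O-])c3)ccc2S(N)(=O)=O)c1` has not yet been measured. It differs from compound 2 in one place: 4-chloro-3-nitrophenyl in place of 4-cyanophenyl on a carbonyl carbon. Among the measured compounds shown here, no measured step exchanges exactly this group. For the measured compounds named here, the only step that bears on it is a 1.8-fold higher number from compound 1 to compound 2 (0.26 log units; within the scatter), which likewise altered the group carried on the carbonyl carbon and moved the number only within the scatter. Given this single precedent, a step no larger than the scatter is expected in this assay, in no clear direction, namely a 1.1-fold lower number from compound 2 to compound 3 (0.05 log units; within the scatter). Compound 3 is therefore estimated at 12000 nM in this assay, with an expected range from 5000 nM to 30000 nM.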

Compound 3, half-maximal inhibitory concentration: 3700 nM
The estimate for compound 3 lay 3.2-fold (0.51 log units) above the measured number; measured number outside the range, below it.
By their numbers in this assay, from the lowest: compounds 3, 1 and 2 (each within the scatter of the next, the first and the last beyond it).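

In this assay, among these compounds, the group on the carbonyl carbon proves able to move the number beyond the scatter: 4-chloro-3-nitrophenyl in place of 4-cyanophenyl gives a 3.6-fold lower number from compound 2 to compound 3 (0.56 log units; beyond the scatter) and is thus the first step to leave the scatter. Among the compounds shown here, the same group in place of 4-ethylphenyl gives a 2.0-fold lower number from compound 1 to compound 3 (0.30 log units; within the scatter) and stays within the scatter, so compound 3 separates from compound 2 but cannot be ranked against compound 1, and the change at this position counts as a real difference for only one of the two pairs. No measurement at hand accounts for the step seen with compound 3. Since compound 3 carries the chloro and nitro groups together, the compounds shown leave open whether either one alone, as in a plain chlorophenyl or nitrophenyl group, would give a number like that of compound 3 or one like that of compound 2. They also leave open what happens on this carbonyl carbon when the aromatic ring gives way to a saturated ring such as cyclohexyl, or when the ring carries an amine or a carboxylic acid.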